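Adenosine series: benzylamino variant in place of furanylmethylamino

The source may report more compounds than this note shows. Statements on the series, on what has been measured and on what is new or still open speak of the compounds shown alone.

Compound 1 `OC[C@H]1O[C@@H](n2cnc3c(NCc4ccco4)ncnc32)[C@H](O)[C@@H]1O` carries a ((furan-2-yl)methyl)amino group on the shared core, and in an assay on isolated protein for binding affinity to Equilibrative nucleoside transporter 1 (Homo sapiens) (on this read-out lower numbers stand for stronger inhibition and higher numbers for weaker inhibition), compound 1 gives 36300 nM, the highest number among the three measured compounds. Compound 2 `Cc1cccc(CSc2ncnc3c2ncn3[C@@H]2O[C@H](CO)[C@@H](O)[C@H]2O)c1` gives 12000 nM and compound 3 `OC[C@H]1O[C@@H](n2cnc3c(CSc4ccccc4F)ncnc32)[C@H](O)[C@@H]1O` gives 355 nM. Compound 4 `O=[N+]([O-])c1ccc(CNc2ncnc3c2ncn3[C@@H]2O[C@H](CO)[C@@H](O)[C@H]2O)c(Cl)c1` differs from compound 1 by 2-chloro-4-nitrophenyl in place of furan-2-yl on a saturated chain carbon bound to a nitrogen on an aromatic ring. Among the compounds with values here, no measured pair keeps the amino link while changing only the aryl part; the two steps from compound 1 exchange the whole substituent: a 3.0-fold lower number from compound 1 to compound 2 (0.48 log units; beyond the scatter) and a 100-fold lower number from compound 1 to compound 3 (2.01 log units; beyond the scatter). Exchanging the furan for a six-membered aromatic ring while the amine is retained looks closer to the first of these, so a modest gain is expected, a 5.2-fold lower number from compound 1 to compound 4 (0.71 log units; beyond the scatter). For compound 4 the estimate is 7000 nM, with a range of 2000 nM to 25000 nM.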

Compound 4, half-maximal inhibitory concentration: 347 nM
Compound 4: middle estimate off by 20-fold (1.30 log units), on the high side; measured number below the stated range.
By their numbers in this assay, from the lowest: compounds 4 and 3 (each within the scatter of the next); then compound 2; then compound 1.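

With the amino link kept, 2-chloro-4-nitrophenyl in place of furan-2-yl gives a 100-fold lower number from compound 1 to compound 4 (2.02 log units; beyond the scatter), so at this position a change of the aryl group alone produces a large step. The earlier steps shown here exchanged the whole substituent, whereas compound 4 shows that no sulfanyl group is needed to reach the level of compound 3, the two lying within the scatter. No measurement shown explains the size of this step. Going by these compounds, it remains open whether the chlorine, the nitro group or both carry the step; an unsubstituted phenyl on the same amino link would be the reference.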